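Adding a methoxy group to compound 2

The source may report more compounds than this note shows. Statements on the series, on what has been measured and on what is new or still open speak of the compounds shown alone.

Compound 1 `NCCCCNc1nc(-c2ccc(F)cc2)nc2ccccc12` gives 64000 nM
Compound 2 `CN(C)CCCNc1nc(-c2ccccc2)nc2ccccc12` gives > 100000 nM as a limit
Compound 3 `CN(C)CCNc1nc(-c2ccc(O)cc2)nc2ccccc12` gives 51000 nM

All three were tested in a toxicity assay on cells (Macrophage, Homo sapiens) for inhibition, read by MTT assay (on this read-out higher numbers stand for weaker inhibition and lower numbers for stronger inhibition), and compound 4 `COc1cccc(-c2nc(NCCCN(C)C)c3ccccc3n2)c1` still awaits measurement there. Compound 2 gives > 100000 nM as a limit, not a number (the limit of > 100000 nM in this assay, at which 1 of the 3 values shown sits). Going from compound 2 to compound 4 places methoxy in place of hydrogen on an aromatic carbon, meta to a large group (methoxy in place of hydrogen on an aromatic carbon). Going by the values given here, no measured pair shows what such a change does, so no step beyond the usual scatter is expected in this assay here. The expected step is an at least 1.1-fold lower number from compound 2 to compound 4 (0.04 log units; that floor lies within the scatter) by this estimate. Compound 3 gives 51000 nM and compound 1 gives 64000 nM in this assay as well, so a real number for the new compound remains possible. Compound 4 is estimated at 90000 nM (expected range 40000 nM to 200000 nM).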

Compound 4, half-maximal inhibitory concentration: 37000 nM
Estimate against measurement, compound 4: 2.4-fold (0.39 log units) above, and the stated range ends above it.
By their numbers in this assay, from the lowest: compounds 4, 3 and 1 (each within the scatter of the next). At a limit, above all of these: compound 2.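

In this assay, going by these compounds alone, replacing phenyl with 3-methoxyphenyl gives an at least 2.7-fold lower number from compound 2 to compound 4 (0.43 log units; beyond the scatter) and so provides the first matched pair here, with a step beyond the scatter. Methoxy on this aromatic carbon, meta to a large group, therefore goes with stronger inhibition in these cells. On these data alone, the true size of the step stays unknown, and only its floor can be read: the limit of > 100000 nM in this assay, at which 1 of the 4 values shown sits.

As far as these compounds go, it remains open whether an amine or a carboxylic acid at this same place would also lower the number. Also open, from the compounds shown here alone, is whether methoxy would do the same on a compound with a longer chain.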